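This account rests on a few compounds, and the source may have more. Where it says the series, first, only, none or still open, it means among the compounds named here.

Series notes. Compound 1 `c1cc(OC2CCCC2)ccc1NC1=NCCO1` and compound 2 `c1cc(OC2CCCCC2)ccc1NC1=NCCO1` share one core; compound 3 `O=C(CCl)NC(=O)Nc1cccc(OC2CCCC2)c1` and compound 4 `O=C(CCl)NC(=O)Nc1cccc(OC2CCCCC2)c1` share another. In a functional assay on MCF7 cells (Homo sapiens) for inhibition, read by sulforhodamine B assay, with a stated time of 48 h (on this read-out lower numbers stand for stronger inhibition of growth and higher numbers for weaker inhibition of growth), compound 1 gives 23100 nM, and compound 2 gives 19100 nM. Between them the change is cyclohexyl in place of cyclopentyl on an oxygen on an aromatic ring, and the step is a 1.2-fold lower number from compound 1 to compound 2 (0.08 log units; within the scatter). Within the data shown here, compound 3 gives 6200 nM in this assay, the lowest of the three numbers so far; the difference between its core and the core of compound 1 is not broken down here. Compound 4 carries the same change against compound 3: cyclohexyl in place of cyclopentyl on an oxygen on an aromatic ring. This is the same change as from compound 1 to compound 2, at the same place, on an oxygen on an aromatic ring, and it has been measured once only. Given a 1.2-fold lower number from compound 1 to compound 2 (0.08 log units; within the scatter), the step from compound 3 to compound 4 is expected to be about a 1.1-fold lower number from compound 3 to compound 4 (0.05 log units; within the scatter), with the caution that a change seen once on one core carries over to another only loosely. Compound 4 is estimated at 5500 nM in this assay, between 2500 nM and 12000 nM.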

Compound 4, concentration for 50% growth inhibition: 6300 nM
For compound 4 the middle estimate is 1.1-fold (0.06 log units) below the measured one; measured number inside the range.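

In this assay the change from cyclopentyl to cyclohexyl on an oxygen on an aromatic ring gives a 1.0-fold higher number from compound 3 to compound 4 (0.01 log units; within the scatter) and agrees with the earlier step on the other core: the same change on two cores in this assay, a 1.2-fold lower number (0.08 log units; within the scatter) from compound 1 to compound 2 and a 1.0-fold higher number (0.01 log units; within the scatter) from compound 3 to compound 4, 1.2-fold (0.09 log units) apart, within the scatter of two such steps. On both cores shown, the change therefore leaves the number within the scatter, and that absence of a clear effect carries from one core to the other. This does not show that a change with a clear effect would carry over in the same way, since neither step moves beyond the scatter, and it says nothing about a third core.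

Still open, as far as these compounds go, is how the series responds when either ring on the oxygen gives way to a different kind of group, such as a methyl, a longer chain or a ring bearing an amine. Also open, from the compounds shown here alone, is whether the agreement between the two cores holds in any other assay, as these compounds are compared here on a single read-out.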